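A few compounds are considered here, and "the series" means these few. Any claim that something is new, unique, unknown or untested is made for them only; others in the source may bear on it.

Compound 1 `CC(=O)N1CCN(c2nc(=O)c3cc(C(F)(F)F)cc([N+](=O)[O-])c3s2)CC1` and compound 2 `CC(C)CC(=O)N1CCN(c2nc(=O)c3cc(C(F)(F)F)cc([N+](=O)[O-])c3s2)CC1` share one core and differ only in the chain on the amide carbonyl. In a physicochemical assay for solubility, read by HPLC (a lower number here means a less soluble compound, a higher number a more soluble compound), compound 1 gives 83.9 ug/mL, and compound 2 gives 66.3 ug/mL, the step of a 1.3-fold lower number from compound 1 to compound 2 (0.10 log units; within the scatter) lying within the scatter. Compound 3 `CCCC(=O)N1CCN(c2nc(=O)c3cc(C(F)(F)F)cc([N+](=O)[O-])c3s2)CC1` differs from compound 2 by hydrogen in place of methyl on a saturated chain carbon bound to two saturated chain carbons. For the measured compounds named here, the single step that bears on this, a 1.3-fold lower number from compound 1 to compound 2 (0.10 log units; within the scatter), was small. For compound 3 the step of a 1.1-fold higher number from compound 2 to compound 3 (0.05 log units; within the scatter) in this assay is therefore expected to stay within the scatter, if anything slightly upward. Compound 3 is estimated at 75 ug/mL, within 45 ug/mL to 125 ug/mL.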

Compound 3, solubility: 2.46 ug/mL
Compound 3: the middle estimate sits 30-fold (1.48 log units) above what was measured; measured number outside the range, below it.
By their numbers in this assay, from the lowest: compound 3; then compounds 2 and 1 (each within the scatter of the next).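

In this assay the loss of one methyl on this saturated chain carbon brings a 27-fold lower number from compound 2 to compound 3 (1.43 log units; beyond the scatter) and ethyl in place of hydrogen brings a 34-fold lower number from compound 1 to compound 3 (1.53 log units; beyond the scatter) so this chain is not a place of small effects only, as the earlier step alone suggested. Compound 3 stands apart from both compound 1 and compound 2, so the number does not follow chain size across these compounds. Nothing available bears on the reason for this. On these data alone, whether the low number belongs to the propylcarbonyl chain alone stays open, as does what a longer chain or an amine at the chain end would give.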